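The compounds below may be only part of what the source reports. "The series", "measured", "known", "first", "only" and "open" are said of these compounds alone.

Compound 1 `CS(=O)(=O)Nc1ccc(CNC(=O)c2ccc(C34CC(C3)C4)cc2)c(Cl)c1` is the starting point of this step. In an assay on HeLa cells for agonist activity at Bile acid receptor (Homo sapiens), read by a luciferase reporter, with a stated time of 24 h (a lower number here means that less compound is needed, a higher number that more compound is needed for the effect), compound 1 gives 560 nM, the second highest of the three numbers measured. Its nearest neighbour is compound 3 `CC(C)Oc1ccc(C(=O)NCc2ccc(NS(C)(=O)=O)cc2Cl)cc1`, which in this assay gives 400 nM; the step of a 1.4-fold lower number from compound 1 to compound 3 (0.15 log units; within the scatter) stays within the scatter. The furthest is compound 2 `CS(=O)(=O)Nc1ccc(CNC(=O)c2ccc(N3CCC3)cc2)c(Cl)c1`, which in this assay gives 13000 nM, a step of a 23-fold higher number from compound 1 to compound 2 (1.37 log units; beyond the scatter) that is large. Between those two, the step of a 33-fold lower number from compound 2 to compound 3 (1.51 log units; beyond the scatter) is large as well.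

The unmeasured compound 4 `CC(C)(O)c1ccc(C(=O)NCc2ccc(NS(C)(=O)=O)cc2Cl)cc1` differs from compound 1 at one place: a group of 4 heavy atoms (3 carbon, 1 oxygen; no ring) in place of a group of 5 heavy atoms (5 carbon; 2 four-membered non-aromatic rings of carbon only), on an aromatic carbon. The entering group, like the isopropoxy of compound 3, has no ring, whereas the azetidin-1-yl of compound 2 does. The two steps that bear on this change therefore point in different directions: the exchange for a group without a ring in compound 3 cost nothing beyond the scatter, while the exchange for the ring-bearing azetidin-1-yl in compound 2 raised the number greatly. Because a 1.4-fold lower number from compound 1 to compound 3 (0.15 log units; within the scatter) lies within the scatter, compound 4 is expected to sit close to compound 1, with a step of a 1.4-fold higher number from compound 1 to compound 4 (0.15 log units; within the scatter) expected in this assay. For compound 4 the estimated value in this assay is 800 nM, within a range of 250 nM to 2500 nM.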

Compound 4, half-maximal effective concentration: 32 nM
The estimate for compound 4 lay 25-fold (1.40 log units) above the measured number; measured number below the stated range.
By their numbers in this assay, from the lowest: compound 4; then compounds 3 and 1 (each within the scatter of the next); then compound 2.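

In this assay, placing 1-hydroxy-1-methylethyl on this aromatic carbon, para to a large group, gives an 18-fold lower number from compound 1 to compound 4 (1.24 log units; beyond the scatter), so this position can take a group with no ring and the number can still fall well beyond the scatter, which compound 3 had not shown. The atom count of the entering group does not settle the outcome: isopropoxy and 1-hydroxy-1-methylethyl both have 4 heavy atoms, 3 carbon and 1 oxygen, yet the exchange gives a 13-fold lower number from compound 3 to compound 4 (1.10 log units; beyond the scatter), and the wider comparison with azetidin-1-yl gives a 410-fold lower number from compound 2 to compound 4 (2.61 log units; beyond the scatter), so the choice of group at this one place spans a very wide range of numbers in this series. Nothing measured here accounts for these differences.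

The compounds shown leave open whether the hydroxyl of 1-hydroxy-1-methylethyl is what matters or whether the branched carbon attached to the ring also contributes. A tert-butyl group, a 1-methoxy-1-methylethyl group or a 1-amino-1-methylethyl group at this position would separate these possibilities.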